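A few compounds are considered here, and "the series" means these few. Any claim that something is new, unique, unknown or untested is made for them only; others in the source may bear on it.

Compound 3 `CCOc1ccc(C(=O)/C=C/c2ccc(C)cc2)cc1` gives, in an assay on isolated protein for inhibition of Amine oxidase [flavin-containing] B (Homo sapiens) (on this read-out higher numbers stand for weaker inhibition and lower numbers for stronger inhibition), a value of 210 nM. Compound 1 `CCOc1ccc(C(=O)/C=C/c2ccc(N(C)C)cc2)cc1` gives 210 nM, and no change at the digits printed from compound 1 to compound 3 (within the scatter), so these two share the highest of the three numbers. Going by the values given here, compound 2 `CCOc1ccc(C(=O)/C=C/c2ccc(F)cc2)cc1` gives 53 nM; a 4.0-fold higher number from compound 2 to compound 3 (0.60 log units; beyond the scatter), which is the only step that separates compound 3 from a neighbour beyond the scatter.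

Compound 4 `CCOc1ccc(C(=O)/C=C/c2ccc(Br)cc2)cc1` differs from compound 3 in one place: bromo in place of methyl on an aromatic carbon. Two measured steps speak to this exchange. The one directly involving the same position and the same leaving group, a 4.0-fold higher number from compound 2 to compound 3 (0.60 log units; beyond the scatter), shows that replacing fluoro, a halogen, with methyl raised the number. The other, a 4.0-fold lower number from compound 1 to compound 2 (0.60 log units; beyond the scatter), shows that the halogen-bearing compound again gave the lower number. Among the compounds with values here, no measured step involves bromo itself, so its effect is inferred from fluoro alone.

Because of a 4.0-fold higher number from compound 2 to compound 3 (0.60 log units; beyond the scatter), compound 4 is expected to land below compound 3 by a modest step, a 2.6-fold lower number from compound 3 to compound 4 (0.42 log units; beyond the scatter). The estimate for compound 4 in this assay is 80 nM, with a likely range from 30 nM to 250 nM.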

Compound 4, half-maximal inhibitory concentration: 210 nM
For compound 4 the middle estimate is 2.6-fold (0.42 log units) below the measured one; the measured number falls inside the stated range.
By their numbers in this assay, from the lowest: compound 2; then compounds 1, 3 and 4 (each within the scatter of the next).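

Here a 4.0-fold higher number from compound 2 to compound 4 (0.60 log units; beyond the scatter) sets bromo apart from fluoro in this assay at this position, while no change at the digits printed from compound 3 to compound 4 (within the scatter) and no change at the digits printed from compound 1 to compound 4 (within the scatter) place bromo level with methyl and dimethylamino. Having a halogen at this aromatic carbon is therefore not enough to give the lower number, and among these four compounds only the fluoro compound, compound 2, stands apart. Nothing available here explains why the two halogens differ.

The compounds shown leave open whether chloro or iodo at this aromatic carbon would fall with fluoro or with bromo, and whether a group such as methoxy, nitrile or a carboxylic acid could match fluoro. They also leave open whether fluoro would keep its lower number on a changed core.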